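Methoxy in place of a bromine on an inactive amide

This account rests on a few compounds, and the source may have more. Where it says the series, first, only, none or still open, it means among the compounds named here.

Compound 3 `O=C(Nc1ccc(Sc2nc3ccccc3s2)c(Cl)c1)c1cc(Br)cc(Br)c1` shares its core with compound 1 `O=C(Nc1ccc(Sc2nc3ccccc3s2)c(Cl)c1)c1cccc(Br)c1` and compound 2 `COc1c(Br)cc(Br)cc1C(=O)Nc1ccc(Sc2nc3ccccc3s2)c(Cl)c1`. In an assay on isolated protein for inhibition of thiosulfate sulfurtransferase (Homo sapiens), with a stated time of 60 min, in the absence of a further agent (a higher number here means a weaker inhibitor, a lower number a stronger inhibitor), compound 3 gives > 100000 nM, which is a limit of the assay rather than a number. Compound 1 likewise gives > 100000 nM in this assay, again a limit. Compound 2 also gives > 100000 nM in this assay, a limit as well. Because all three values sit at the limit of > 100000 nM in this assay, at which 3 of the 3 values shown sit, the three steps among them cannot be read: a step that the two limits leave unreadable from compound 1 to compound 3, a step that the two limits leave unreadable from compound 2 to compound 3 and a step that the two limits leave unreadable from compound 1 to compound 2. Compound 3 therefore stands level with the other two at the limit, and none of the three can be called more or less potent than another.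

Compound 4 `COc1ccc(Br)cc1C(=O)Nc1ccc(Sc2nc3ccccc3s2)c(Cl)c1` differs from compound 3 by 5-bromo-2-methoxyphenyl in place of 3,5-dibromophenyl on a carbonyl carbon. The two measured steps that alter the group on the carbonyl carbon, a step that the two limits leave unreadable from compound 1 to compound 2 and a step that the two limits leave unreadable from compound 2 to compound 3, bear on this change, and each was unreadable because both of its ends sit at the limit of > 100000 nM in this assay, at which 3 of the 3 values shown sit. Within the data shown here, no measured step gives a direction, so no shift beyond the scatter is expected in this assay, and compound 4 is expected to remain at or near the limit. Compound 4 is estimated at 150000 nM, with a range from 30000 nM to 1000000 nM. The step this estimate means is expected to be a step that the limit leaves unreadable from compound 3 to compound 4.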

Compound 4, half-maximal inhibitory concentration: > 100000 nM
Compound 4: a limit, no number (the forecaster's own chance of this, stated with the estimate: 85%); the middle value is on the limit's open side.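

Compound 4 gives > 100000 nM in this assay and this is a limit of the assay. Its steps to compound 1, compound 2 and compound 3 cannot be read, because all four compounds sit at the same limit: the limit of > 100000 nM in this assay, at which 4 of the 4 values shown sit.

In this assay the compounds shown leave open how far past the limit each of the four lies and whether any group on the carbonyl carbon gives a readable inhibition.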